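The source may report more compounds than this note shows. Statements on the series, on what has been measured and on what is new or still open speak of the compounds shown alone.

Measured set in a functional assay on HepG2 cells (Homo sapiens) for antiproliferative activity, read by CCK-8 assay, with a stated time of 48 h; on this read-out lower numbers stand for stronger inhibition and higher numbers for weaker inhibition:
- compound 1 `O=C(Nc1ccccc1)c1cc(Oc2ccc(/C=C/c3ccncc3)cc2)ccn1` gives > 100000 nM, which is a limit of this assay
- compound 2 `O=C(Nc1ccc(Cl)cc1)c1cc(Oc2ccc(/C=C/c3ccncc3)cc2)ccn1` gives 56200 nM
- compound 3 `O=C(NCc1ccccc1)c1cc(Oc2ccc(/C=C/c3ccncc3)cc2)ccn1` gives 28900 nM

Of the two numbers, compound 3 carries the smaller one, though a 1.9-fold lower number from compound 2 to compound 3 (0.29 log units; within the scatter). Compound 1 stands at the limit of > 100000 nM in this assay, at which 1 of the 3 values shown sits. Compound 4 `CC(C)NC(=O)c1cc(Oc2ccc(/C=C/c3ccncc3)cc2)ccn1` differs from compound 3 in one place: isopropyl in place of benzyl on an amide-type nitrogen. Within the data shown here, no measured step covers an isopropyl on this nitrogen; the steps seen, an at least 3.4-fold lower number from compound 1 to compound 3 (0.53 log units; beyond the scatter) and an at least 1.7-fold lower number from compound 1 to compound 2 (0.25 log units; that floor lies within the scatter), concern phenyl, 4-chlorophenyl and benzyl amides only, so they bear on compound 4 at most indirectly. The expectation is therefore for no shift beyond the scatter, or a slight rise, estimated as a 1.4-fold higher number from compound 3 to compound 4 (0.14 log units; within the scatter). Compound 4 is expected at 40000 nM, with a range from 15000 nM to 100000 nM.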

Compound 4, half-maximal inhibitory concentration: 33700 nM
Compound 4: middle estimate off by 1.2-fold (0.07 log units), on the high side; the range from low to high includes it.
By their numbers in this assay, from the lowest: compounds 3, 4 and 2 (each within the scatter of the next). At a limit, above all of these: compound 1.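

Isopropyl on the amide-type nitrogen has no ring, yet in place of benzyl it gives a 1.2-fold higher number from compound 3 to compound 4 (0.07 log units; within the scatter), and in place of 4-chlorophenyl it gives a 1.7-fold lower number from compound 2 to compound 4 (0.22 log units; within the scatter), so among these compounds an aromatic ring on this nitrogen is not needed to stay in this range. In place of phenyl, isopropyl gives an at least 2.9-fold lower number from compound 1 to compound 4 (0.47 log units; beyond the scatter). Compound 1 stands at a limit, so that step is only a floor: the limit of > 100000 nM in this assay, at which 1 of the 4 values shown sits.

As far as these compounds go, whether a longer chain or a chain ending in an amine or a carboxylic acid on this nitrogen would shift the number beyond the scatter stays open. So does the effect of any change on the shared core.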